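The source may hold more compounds than are shown below. What is called first, only, known or untested is meant among the compounds shown, and "the series" means these compounds.

Two members of this series have a number in a functional assay on DU-145 cells (Homo sapiens) for inhibition; a higher number here means a weaker inhibitor, a lower number a stronger inhibitor. Compound 1, `Oc1cccc(-c2cc(-c3ccc(F)cc3)cc(-c3cccc(O)c3)n2)c1`, carries two 3-hydroxyphenyl groups on its shared core, and in this assay compound 1 gives 7120 nM. Compound 2, `Oc1cccc(-c2cc(-c3ccc(OC(F)(F)F)cc3)cc(-c3ccccc3O)n2)c1`, carries one 3-hydroxyphenyl group and one 2-hydroxyphenyl group, and in this assay compound 2 gives 21100 nM. Of the two numbers, compound 2 has the highest; the nearest is compound 1, whose number is lower by an amount beyond the usual scatter.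

Compound 3, `Oc1cccc(-c2cc(-c3ccc(OC(F)(F)F)cc3)cc(-c3cccc(O)c3)n2)c1`, has the same atoms as compound 2, joined differently: 3-hydroxyphenyl in place of 2-hydroxyphenyl on an aromatic carbon. For the measured compounds named here, no step between two measured compounds in this assay follows that same change, so the expectation rests on what compound 1 and compound 2 show. Compound 3 and compound 1 share the pair of 3-hydroxyphenyl groups, and compound 1 gives 7120 nM, so a step downward from compound 2 is expected. Compound 3 is expected to give 9000 nM, with a likely range from 3500 nM to 25000 nM. The step of a 2.3-fold lower number from compound 2 to compound 3 (0.37 log units; beyond the scatter) is thus expected to be modest, roughly at or a little beyond the scatter, toward a stronger inhibitor.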

Compound 3, half-maximal inhibitory concentration: > 50000 nM
Compound 3 was reported as a limit; the forecaster's own chance of this, stated with the estimate: 5%; middle value at least 5.5-fold (0.74 log units) from the limit.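

Compound 3 stands at a limit of the assay rather than at a number, so both steps from it are minimum sizes: the limit of > 50000 nM in this assay, at which 1 of the 3 values shown sits.

For the compounds shown here, at the place next to the ring nitrogen, 3-hydroxyphenyl in place of 2-hydroxyphenyl gives an at least 2.3-fold higher number from compound 2 to compound 3 (0.37 log units; beyond the scatter), so with trifluoromethoxy on the other aryl group, the position of the hydroxyl on this ring clearly matters, and the 2-hydroxyphenyl compound is the one with a measured value. The pair of 3-hydroxyphenyl groups therefore does not by itself bring a stronger inhibitor, since trifluoromethoxy in place of fluoro gives an at least 7.0-fold higher number from compound 1 to compound 3 (0.84 log units; beyond the scatter), which shows that the outer substituent also counts when that pair is held constant.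

From the compounds shown here alone, it remains open whether 2-hydroxyphenyl at this place would read the same way alongside fluoro, so the two changes cannot be separated beyond these single steps, and the reason for either step stays unknown. Going by these compounds, how an amine, a methoxy group or a carboxylic acid in place of the hydroxyl on this ring would read also stays open.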